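Swapping methyl for chloro on a hydroxamic acid inhibitor

This account rests on a few compounds, and the source may have more. Where it says the series, first, only, none or still open, it means among the compounds named here.

Measured compounds:
Compound 1 `Cc1ccc(C(=O)c2ccc3c(ccn3Cc3ccc(C(=O)NO)cc3)c2)cc1`: 1490 nM
Compound 2 `COc1ccc(C(=O)c2ccc3c(ccn3S(=O)(=O)c3cccc(/C=C/C(=O)NO)c3)c2)cc1OC`: 1420 nM
Compound 3 `COc1ccc(C(=O)c2ccc3c(ccn3S(=O)(=O)c3ccc(/C=C/C(=O)NO)cc3)c2)cc1`: 10000 nM

Of the compounds shown here, three have been measured in an assay on isolated protein for inhibition of histone deacetylase 8 (Homo sapiens); a lower number here means a stronger inhibitor, a higher number a weaker inhibitor. Compound 1 gives 1490 nM, which is the second highest of the three numbers. Compound 2 gives 1420 nM, and this lies within the usual scatter of compound 1, so the two cannot be told apart. Compound 3 gives 10000 nM, a clearly higher number than compound 1, beyond the scatter.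

The new compound 4 `O=C(NO)c1ccc(Cn2ccc3cc(C(=O)c4ccc(Cl)cc4)ccc32)cc1` is compound 1 with one change: chloro in place of methyl on an aromatic carbon. The group that leaves and the group that enters are each a single heavy atom, and neither carries a hydrogen-bond donor or acceptor or a charge. Within the data shown here, no measured pair in this set shows what such a change does, so there is no basis for predicting a shift in either direction beyond the scatter in this assay. The expected step from compound 1 to compound 4 is therefore small, a 1.1-fold lower number from compound 1 to compound 4 (0.06 log units; within the scatter). Compound 4 is estimated at 1300 nM, with a range from 500 nM to 3500 nM.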

Compound 4, half-maximal inhibitory concentration: 1060 nM
For compound 4 the middle estimate is 1.2-fold (0.09 log units) above the measured one; the measured number falls inside the stated range.
By their numbers in this assay, from the lowest: compounds 4, 2 and 1 (each within the scatter of the next); then compound 3.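

Read across the pair in this assay, the swap gives a 1.4-fold lower number from compound 1 to compound 4 (0.15 log units; within the scatter) and is the first direct reading of this position in the set. On this six-membered aromatic ring, para to a large group, 4-chlorophenyl in place of 4-methylphenyl leaves compound 4 indistinguishable from compound 1, so this position accepts this exchange of one heavy atom for another without a measurable shift. No supporting measurement bears on why the two compounds read alike.

On these data alone, whether the same position would accept something less like methyl, such as an amine, a carboxylic acid or a longer chain, remains open. Also open, as far as these compounds go, is whether chloro in place of methyl would read the same way on the core of compound 3, where the number is clearly higher.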